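This account rests on a few compounds, and the source may have more. Where it says the series, first, only, none or still open, it means among the compounds named here.

Measured so far:
compound 1 `COc1ccc(C(=O)c2ccc3c(ccn3S(=O)(=O)c3cccc(/C=C/C(=O)NO)c3)c2)cc1OC` — 1420 nM
compound 2 `COc1ccc(C(=O)c2ccc3c(ccn3S(=O)(=O)c3ccc(/C=C/C(=O)NO)cc3)c2)cc1` — 10000 nM

Within the data shown here, in an assay on isolated protein for inhibition of histone deacetylase 8 (Homo sapiens) (on this read-out lower numbers stand for stronger inhibition and higher numbers for weaker inhibition), compound 2 gives the highest of the two numbers; compound 1, the only other measured compound, sits at a lower value, and the two differ in more than one place, so no single step is drawn between them. Compound 3 `COc1cc(C(=O)c2ccc3c(ccn3S(=O)(=O)c3ccc(/C=C/C(=O)NO)cc3)c2)cc(OC)c1OC` has not been measured. It differs from compound 2 by 3,4,5-trimethoxyphenyl in place of 4-methoxyphenyl on a carbonyl carbon. Among the measured compounds shown here, no step between measured compounds covers this change, and the gap between compound 1 and compound 2 cannot be assigned to the extra methoxy groups alone. Given compound 1 with 1420 nM, a step toward a lower number is expected for compound 3, of moderate size, a 2.0-fold lower number from compound 2 to compound 3 (0.30 log units; within the scatter), with wide uncertainty. Compound 3 is estimated at 5000 nM in this assay, within a range of 1500 nM to 15000 nM.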

Compound 3, half-maximal inhibitory concentration: 5340 nM
Compound 3: the middle estimate sits 1.1-fold (0.03 log units) below what was measured, within the range that was stated.
By their numbers in this assay, from the lowest: compound 1; then compounds 3 and 2 (each within the scatter of the next).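

Among these compounds, the change to 3,4,5-trimethoxyphenyl in place of 4-methoxyphenyl on a carbonyl carbon reads as a 1.9-fold lower number from compound 2 to compound 3 (0.27 log units; within the scatter) in this assay and is the only single-place step available. At this place, the group can therefore go from 8 to 12 heavy atoms and from 1 to 3 hydrogen-bond acceptors without a step beyond the scatter. No measurement shown accounts for this result.

From the compounds shown here alone, whether a 4-aminophenyl or 4-carboxyphenyl group on the same carbonyl carbon would give a step beyond the scatter remains open. Compound 1 differs from compound 2 and compound 3 in more than one place, so the contribution of each difference to its value cannot be separated.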